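The source may hold more compounds than are shown below. What is called first, only, known or untested is meant among the compounds shown, and "the series" means these compounds.

Measured compounds:
compound 1, `COc1cc(-c2cc(/C=C/C(=O)c3ccc(N)cc3)[nH]n2)cc(OC)c1OC`: 101%
compound 2, `COc1cc(-c2cc(/C=C/C(=O)c3ccc(Cl)c(Cl)c3)[nH]n2)cc(OC)c1OC`: 103%
compound 3, `COc1ccc(C(=O)/C=C/c2cc(-c3cc(OC)c(OC)c(OC)c3)n[nH]2)cc1OC`: 100%

In a functional assay on OVCAR-3 cells (Homo sapiens) for cytotoxicity, read by sulforhodamine B assay, with a stated time of 48 h, tested at 0.01 uM (on this read-out higher numbers stand for a weaker effect at the one concentration tested and lower numbers for a stronger effect), compound 3 holds the lowest of the three numbers, yet it lies within the scatter of both others: compound 1 is the nearest and compound 2 the furthest, and neither gap exceeds the usual spread of repeats. All three compounds share one core and differ only in the aryl group on the carbonyl carbon.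

Compound 4, `COc1cc(-c2cc(/C=C/C(=O)c3ccc(F)c(F)c3)[nH]n2)cc(OC)c1OC`, is not yet measured in this assay. It differs from compound 3 in one place: 3,4-difluorophenyl in place of 3,4-dimethoxyphenyl on a carbonyl carbon.

For the measured compounds named here, three measured steps bear on this change, since each swaps the aryl group on the same carbonyl carbon: a number 2 percentage points higher from compound 1 to compound 2 (within the scatter), a number 1 percentage points lower from compound 1 to compound 3 (within the scatter) and a number 3 percentage points lower from compound 2 to compound 3 (within the scatter). Every one of them stays within the scatter, and the compounds with two halogens on that aryl group, compound 2, and with two methoxy groups, compound 3, sit close together. No step beyond the scatter is therefore expected in this assay for compound 4 in either direction; the expected step is a number 1 percentage points higher from compound 3 to compound 4 (within the scatter).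

The estimate for compound 4 in this assay is 101%, with a range from 94% to 108%.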

Compound 4, a percentage reported as activity, at one concentration (the size of the read-out at that concentration, not a potency): 102%
Beside the measured number, compound 4's estimate is 1 percentage points below it; measured number inside the range.
By their numbers in this assay, from the lowest: compounds 3, 1, 4 and 2 (each within the scatter of the next).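

Notes on the aryl group on the carbonyl carbon: in this assay, the 3,4-difluorophenyl group gives a number 2 percentage points higher from compound 3 to compound 4 (within the scatter), a number 1 percentage points lower from compound 2 to compound 4 (within the scatter) and a number 1 percentage points higher from compound 1 to compound 4 (within the scatter), so the fourth aryl group also leaves the series without a step beyond the scatter. The step from compound 3 to compound 4 goes from 10 heavy atoms to 8 and from 2 hydrogen-bond acceptors to 0, and this difference in the group on the carbonyl carbon has no readable consequence at the one concentration tested. Nothing available explains why the numbers stay together at this position.

The compounds shown leave open whether a group of another kind on the carbonyl carbon, such as a longer alkyl chain in place of the aryl ring or a phenyl ring carrying a carboxylic acid, would give a step beyond the scatter. Also open, as far as these compounds go, is whether the four compounds would separate at other concentrations, as a reading at a single concentration gives no potency for any of them.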